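The source may hold more compounds than are shown below. What is called first, only, known or untested is meant among the compounds shown, and "the series" means these compounds.

For the measured compounds named here, compound 2 `CCCCc1cc2nn(-c3ccccc3)cc2cn1` gives 6700 nM in a functional assay on K562 cells (Homo sapiens) for inhibition, read by fluorescence, with a stated time of 72 h (a higher number here means a weaker inhibitor of growth, a lower number a stronger inhibitor of growth), at one end of the two numbers so far; compound 1 `CCCCc1cc2nn(-c3ccccc3)cc2c(C(C)C)n1` gives 12900 nM, and the step of a 1.9-fold lower number from compound 1 to compound 2 (0.28 log units; within the scatter) lies within the scatter. Compound 3 `c1ccc(-n2cc3cnc(C4CC4)cc3n2)cc1` differs from compound 2 by cyclopropyl in place of butyl on an aromatic carbon. Going by the values given here, no measured step concerns this change: the single step on record, a 1.9-fold lower number from compound 1 to compound 2 (0.28 log units; within the scatter), touches another group and was itself within the scatter, so nothing here points to a move beyond the scatter. Compound 3 is therefore expected to give about 8000 nM in this assay, in the range 3000 nM to 25000 nM. The expected step is a 1.2-fold higher number from compound 2 to compound 3 (0.08 log units; within the scatter), within the scatter.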

Compound 3, concentration for 50% growth inhibition: 60500 nM
Estimate against measurement, compound 3: 7.6-fold (0.88 log units) below; measured number above the stated range.
By their numbers in this assay, from the lowest: compounds 2 and 1 (each within the scatter of the next); then compound 3.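

In this assay, for the compounds shown here, the aromatic carbon next to the ring nitrogen responds to its substituent: cyclopropyl in place of butyl gives a 9.0-fold higher number from compound 2 to compound 3 (0.96 log units; beyond the scatter), the first step beyond the scatter. Butyl has no ring and cyclopropyl has one, so chain and ring differ together in this single step. Nothing measured here accounts for the step. Going by these compounds, whether a longer chain or a cyclobutyl ring at this carbon would stay near compound 2 remains open. So does the response to an amine there.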